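A Second Methyl on the Ethoxycarbonyl-Bearing Carbon

A few compounds are considered here, and "the series" means these few. Any claim that something is new, unique, unknown or untested is made for them only; others in the source may bear on it.

Of the compounds shown here, two sharing one core have been measured in a functional assay on microsomes for inhibition, read by spectrophotometry, tested at 200 ug/mL; on this read-out lower numbers stand for less inhibition and higher numbers for more inhibition at the one concentration tested (going by the name of the read-out). Compound 1 `CCOC(=O)CCCOc1ccc(NC(=O)COc2ccc3ccccc3c2)cc1` gives 29%. Compound 2 `CCOC(=O)C(C)Oc1ccc(NC(=O)COc2ccc3ccccc3c2)cc1` gives 22%; the step of a number 7 percentage points lower from compound 1 to compound 2 (within the scatter) lies within the scatter, so compound 2, although its number is the smaller of the two, stands level with compound 1. Compound 3 `CCOC(=O)C(C)(C)Oc1ccc(NC(=O)COc2ccc3ccccc3c2)cc1` has not yet been measured. It differs from compound 2 by methyl in place of hydrogen on a saturated chain carbon bound to a carbonyl carbon, an oxygen on an aromatic ring and a saturated chain carbon. For the measured compounds named here, the only step known, from compound 1 to compound 2, altered the same ethoxycarbonyl-bearing chain on the oxygen on the aromatic ring and stayed within the scatter, so it bears on this change only loosely and suggests that chain can be altered without a large shift. On that basis, the step of no change at the digits printed from compound 2 to compound 3 (within the scatter) is expected to fall within the scatter, with no clear direction. Compound 3 is therefore estimated at 22%, with a range from 10% to 35%.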

Compound 3, a percentage reported as inhibition, at one concentration (the size of the read-out at that concentration, not a potency): 22%
Estimate against measurement, compound 3: no gap at the digits printed, within the range that was stated.
By their numbers in this assay, from the lowest: compounds 2, 3 and 1 (each within the scatter of the next).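

In this assay, the step from hydrogen to methyl on this saturated chain carbon bound to a carbonyl carbon, an oxygen on an aromatic ring and a saturated chain carbon reads no change at the digits printed from compound 2 to compound 3 (within the scatter) and so leaves the read-out level. The comparison of the 3-(ethoxycarbonyl)propyl and 1-(ethoxycarbonyl)-1-methylethyl groups on the oxygen reads a number 7 percentage points lower from compound 1 to compound 3 (within the scatter) and is likewise no shift beyond the scatter, so all three chains stand level at the one concentration tested. Nothing available explains why this added methyl leaves the read-out level.

The compounds shown leave open whether a carboxylic acid in place of the ethyl ester would move the number beyond the scatter. They also leave open what an amine on this chain carbon, or a longer chain in place of the added methyl, would do.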